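Hydroxy to nitro in the series: notes on compound 3

This account rests on a few compounds, and the source may have more. Where it says the series, first, only, none or still open, it means among the compounds named here.

Measured in a functional assay on NCI-H460 cells (Homo sapiens) for cytotoxicity, read by sulforhodamine B assay, with a stated time of 72 h; a lower number here means a stronger inhibitor, a higher number a weaker inhibitor
- compound 1 `COc1ccc(/C=C(/F)c2cc(OC)c(OC)c(OC)c2)cc1O` gives 1.1 nM as its value
- compound 2 `COc1ccc(/C(F)=C\c2cc(OC)c(OC)c(OC)c2)cc1[N+](=O)[O-]` gives 379 nM as its value

Compound 1 holds the lower of the two numbers, which makes it the stronger inhibitor of the pair, and the gap to compound 2 lies beyond the scatter. Compound 3 `COc1ccc(/C=C(/F)c2cc(OC)c(OC)c(OC)c2)cc1[N+](=O)[O-]` has not yet been measured. It differs from compound 1 in one place (nitro in place of hydroxy on an aromatic carbon), with nitro in place of hydroxy on an aromatic carbon, ortho to a methoxy group and meta to a large group.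

Going by the values given here, no measured step isolates this change in this assay and the guide is thin. Compound 2 also carries a nitro group and gives 379 nM as its value, well above that of compound 1. A weaker inhibitor is therefore expected, by a margin beyond the scatter. The expected size is a 27-fold higher number from compound 1 to compound 3 (1.44 log units; beyond the scatter) in the upward direction. The estimate for compound 3 is 30 nM with an expected range from 3 nM to 300 nM as its bounds.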

Compound 3, half-maximal inhibitory concentration: 42.6 nM
Estimate against measurement, compound 3: 1.4-fold (0.15 log units) below; measured number inside the range.
By their numbers in this assay, from the lowest: compound 1; then compound 3; then compound 2.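

In this assay, nitro in place of hydroxy on an aromatic carbon, ortho to a methoxy group and meta to a large group, now has a direct reading: a 39-fold higher number from compound 1 to compound 3 (1.59 log units; beyond the scatter), a large step beyond the scatter. The position is therefore sensitive to the group it carries, although hydroxy is not essential for activity, since compound 3 still gives 42.6 nM. The change removes the hydrogen-bond donor and brings in a larger group with more hydrogen-bond acceptors, and this single step cannot separate these differences, while no supporting data bear on what lies behind the loss.

An amine or a carboxylic acid at this position would help show whether the value of compound 1 depends specifically on hydroxy or can be approached by other groups. Going by these compounds alone, it also remains open whether the same step would have a similar size with other substituents on the core of compound 1, as only this one pair isolates the change.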